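Cyclohexyl in place of tert-butyl: expected cytotoxicity step

The compounds below may be only part of what the source reports. "The series", "measured", "known", "first", "only" and "open" are said of these compounds alone.

In an ADME assay on C8166 cells (Homo sapiens) for cytotoxicity, read by MTT assay (a lower number here means that less compound is tolerated, a higher number that more compound is tolerated), compound 3 (`CC(C)(C)n1cc(C(=O)O)c(=O)c2c(O)c(Cc3cccc(Cl)c3F)ccc21`) stands highest at 400000 nM against compound 1 (`CCCn1cc(C(=O)O)c(=O)c2c(O)c(Cc3cccc(Cl)c3F)ccc21`) at 24200 nM and compound 2 (`CC(C)Cn1cc(C(=O)O)c(=O)c2c(O)c(Cc3cccc(Cl)c3F)ccc21`) at 19500 nM in the same assay. Compound 4 (`O=C(O)c1cn(C2CCCCC2)c2ccc(Cc3cccc(Cl)c3F)c(O)c2c1=O`) carries cyclohexyl in place of tert-butyl on an aromatic nitrogen. Both a 17-fold higher number from compound 1 to compound 3 (1.22 log units; beyond the scatter) and a 21-fold higher number from compound 2 to compound 3 (1.31 log units; beyond the scatter) are large, while a 1.2-fold lower number from compound 1 to compound 2 (0.09 log units; within the scatter) stays within the scatter. Among the three measured compounds, only the tert-butyl compound stands apart, and none carries a ring at this place, so the expectation stays loose. A clear fall is expected, with an estimated 10-fold lower number from compound 3 to compound 4 (1.00 log units; beyond the scatter) in this assay as the likely size. For compound 4 the estimate is 40000 nM with an expected range from 13000 nM to 180000 nM for the measurement.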

Compound 4, half-maximal cytotoxic concentration: 17400 nM
Compound 4: the middle estimate sits 2.3-fold (0.36 log units) above what was measured, and the stated range covers the measured number.
By their numbers in this assay, from the lowest: compounds 4, 2 and 1 (each within the scatter of the next); then compound 3.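

At this aromatic nitrogen, the six-membered ring of cyclohexyl does not retain the high number seen with tert-butyl: in this assay the change gives a 23-fold lower number from compound 3 to compound 4 (1.36 log units; beyond the scatter). Cyclohexyl cannot be told apart from the isobutyl and propyl chains, with a 1.1-fold lower number from compound 2 to compound 4 (0.05 log units; within the scatter) and a 1.4-fold lower number from compound 1 to compound 4 (0.14 log units; within the scatter), so compound 3 alone stands apart among the four compounds. No evidence at hand explains this result. On these data alone, whether the high number is peculiar to tert-butyl remains open. Isopropyl, cyclopropyl or phenyl on this nitrogen would help to settle that.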